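Compound 1 gives up its 2,4-difluorophenyl group

This account rests on a few compounds, and the source may have more. Where it says the series, first, only, none or still open, it means among the compounds named here.

For the measured compounds named here, in a toxicity assay on HepG2 2.2.15 cells (Homo sapiens) for cytotoxicity, read by CellTiter-Glo (a higher number here means that more compound is tolerated, a lower number that less compound is tolerated), compound 1 (`O=C(Nc1cc(F)c(F)c(F)c1)N1Cc2c(-c3ccc(F)cc3F)cnn2CC1C1CC1`) gives 32100 nM as the lower of the two numbers so far. Compound 2 (`CC1CN(C(=O)Nc2cc(F)c(F)c(F)c2)Cc2c(N3CC(C#N)CC3=O)cnn21`) stands higher at 115000 nM by a gap beyond the usual scatter. Compound 3 (`O=C1CC(c2cnco2)CN1c1cnn2c1CN(C(=O)Nc1cc(F)c(F)c(F)c1)C(C1CC1)C2`) has not yet been measured. It carries 4-(1,3-oxazol-5-yl)-2-oxopyrrolidin-1-yl in place of 2,4-difluorophenyl on an aromatic carbon of the core of compound 1. Going by the values given here, no measured pair isolates this change, so the expectation is loose. Among the compounds with values here, the one guide is compound 2, which also lacks the 2,4-difluorophenyl group and reads 115000 nM in this assay but differs from compound 1 in more than one place. The expected step of a 2.6-fold higher number from compound 1 to compound 3 (0.42 log units; beyond the scatter) is upward and probably beyond the scatter. For compound 3 the estimated value is 85000 nM with an expected range from 35000 nM to 200000 nM around it.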

Compound 3, half-maximal cytotoxic concentration: 139000 nM
Compound 3: the middle estimate sits 1.6-fold (0.21 log units) below what was measured, and the stated range covers the measured number.
By their numbers in this assay, from the lowest: compound 1; then compounds 2 and 3 (each within the scatter of the next).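

Compounds 1 and 3 form the first pair shown that differ in one place, so the effect of this position can now be read directly. In this assay, 4-(1,3-oxazol-5-yl)-2-oxopyrrolidin-1-yl in place of 2,4-difluorophenyl gives a 4.3-fold higher number from compound 1 to compound 3 (0.64 log units; beyond the scatter), showing that this aromatic carbon of the shared core influences how much compound is tolerated when the rest of compound 1 stays the same. No measurement shown here accounts for the size or direction of this step.

The compounds shown leave open whether the oxazole, the 2-oxopyrrolidine ring or simply the loss of the 2,4-difluorophenyl group carries the step, since all of these change together. A plain 2-oxopyrrolidin-1-yl group or a morpholine at this carbon would help separate those parts.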